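Ethyl for tert-butyl beside the ketone of compound 2

This account rests on a few compounds, and the source may have more. Where it says the series, first, only, none or still open, it means among the compounds named here.

Compound 1 `Cc1c(OCCCCOc2ccc(C(=O)O)cc2Cl)ccc(C(=O)CC2CCCC2)c1O`: 27.4%
Compound 2 `Cc1c(OCCCCOc2ccc(C(=O)CC(C)(C)C)c(O)c2C)cccc1C(=O)O`: 109%
Compound 3 `Cc1c(OCCCCOc2ccc(F)c(C(=O)O)c2)ccc(C(=O)CC(C)(C)C)c1O`: 102%

In an assay on HEK293 cells for positive allosteric modulation of metabotropic glutamate receptor 3 (Rattus norvegicus), read by thallium flux, with a stated time of 2.5 min (a higher number here means a larger maximal response, a lower number a smaller maximal response), compound 2 gives the highest of the three numbers. Compound 3 is nearest, and a number 7 percentage points lower from compound 2 to compound 3 (within the scatter). Among the compounds with values here, compound 1 is furthest, and its value stands well beyond the scatter below that of compound 2, but the two structures differ in more than one place, so no single step is given for that pair.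

Compound 4 `CCCC(=O)c1ccc(OCCCCOc2cccc(C(=O)O)c2C)c(C)c1O` is not yet measured. Relative to compound 2 the change is ethyl in place of tert-butyl on a saturated chain carbon bound to a carbonyl carbon. Within the data shown here, none of the measured steps alters this part of the molecule, so the expectation rests on the unchanged rest of compound 2. Compound 4 is expected to reach 88%, between 50% and 115%, so the estimated step is a number 21 percentage points lower from compound 2 to compound 4 (beyond the scatter).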

Compound 4, largest response reached (reported as percent of maximum), in percent of the reference or control that the assay uses: 53%
Compound 4: the middle estimate sits 35 percentage points above what was measured, and the stated range covers the measured number.
By their numbers in this assay, from the lowest: compound 1; then compound 4; then compounds 3 and 2 (each within the scatter of the next).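

In this assay ethyl in place of tert-butyl on a saturated chain carbon bound to a carbonyl carbon gives a number 56 percentage points lower from compound 2 to compound 4 (beyond the scatter) and so shows that the maximal response of compound 2 depends on this group. The only earlier step, a number 7 percentage points lower from compound 2 to compound 3 (within the scatter) and made elsewhere in the molecule, had not shown a change of this kind. Nothing available accounts for the loss. Going by these compounds, whether isopropyl or cyclohexyl on that carbon would restore the response remains open, as does the effect of an amine there.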